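Swapping a Propyl Chain for a Fused Ring Pair

The source may hold more compounds than are shown below. What is called first, only, known or untested is meant among the compounds shown, and "the series" means these compounds.

Three ureas have been tested so far in a functional assay on the whole organism (blood) with Rattus norvegicus as the target, with stated times of 24 h and 1 h, at a dose of 15 mg/kg by the intraperitoneal route; a higher number here means a stronger effect of the compound at the dose given, a lower number a weaker effect. Compound 1 `O=C(NC[C@@H]1C[C@@H]2C=C[C@@H]1C2)NS(=O)(=O)N1CCC(CCNC(=O)c2cnccc2Cl)CC1` gives 12%, compound 2 `CC#N.O=C(NC[C@@H]1C[C@@H]2CC[C@@H]1O2)NS(=O)(=O)N1CCC(CCNC(=O)c2nc3ccccc3s2)CC1` gives 30%, and compound 3 `CCCNC(=O)NS(=O)(=O)N1CCC(CCNC(=O)c2cccc3c2OCCO3)CC1` gives 25%. On these numbers compound 3 stands second highest of the three: compound 2 differs from it by an amount within the scatter, whereas compound 1 lies lower by an amount beyond it.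

Compound 4 `O=C(NC[C@@H]1C[C@@H]2CC[C@@H]1O2)NS(=O)(=O)N1CCC(CCNC(=O)c2cccc3c2OCCO3)CC1` is the next candidate for this assay. It differs from compound 3 in one place: a group of 7 heavy atoms (6 carbon, 1 oxygen; 2 five-membered non-aromatic rings with 1 hetero atom each) in place of a group of 2 heavy atoms (2 carbon; no ring), on a saturated chain carbon bound to an amide-type nitrogen. Within the data shown here, no pair of measured compounds isolates this change. Compound 2 carries the same group of 7 heavy atoms and gives 30%. The step from compound 3 to compound 4 is therefore expected to be small, a number 3 percentage points higher from compound 3 to compound 4 (within the scatter), within the scatter. Compound 4 is estimated at 28%, with a range from 10% to 48%.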

Compound 4, a percentage reported as activity, at one dose (the size of the read-out at that dose, not a potency): 13%
Estimate against measurement, compound 4: 15 percentage points above, within the range that was stated.
By their numbers in this assay, from the lowest: compounds 1 and 4 (each within the scatter of the next); then compounds 3 and 2 (each within the scatter of the next).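

In this assay, the position now has its first direct reading: a number 12 percentage points lower from compound 3 to compound 4 (beyond the scatter), so at this dose the two-ring group does not match the ethyl it replaces when the rest of the molecule stays the same. Compound 2 carries the same two-ring group with a different amide and gives 30%, so this group does not always go with a low number. No measurement here explains the drop. From the compounds shown here alone, whether a butyl chain or a cyclohexyl ring at this position would give a number nearer that of compound 3 remains open.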